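A few compounds are considered here, and "the series" means these few. Any claim that something is new, unique, unknown or untested is made for them only; others in the source may bear on it.

Measured compounds in a functional assay on SW-620 cells (Homo sapiens) for antiproliferative activity, read by MTT assay, with a stated time of 24 h; a higher number here means a weaker inhibitor, a lower number a stronger inhibitor:
- Compound 1 `CCN(CC)c1ccc(/C=C/C(=O)c2ccc(OC)c3c2OC(C)(C)C=C3)cc1` gives 670 nM in this assay.
- Compound 2 `COc1ccc(C(=O)/C=C/c2ccsc2)c2c1C=CC(C)(C)O2` gives only a limit of the assay, > 10000 nM.
- Compound 3 `COc1ccc(C(=O)/C=C/c2ccco2)c2c1C=CC(C)(C)O2` likewise gives only a limit, > 10000 nM.

Compound 3 therefore stands at the edge of what this assay reports: its value is a limit, not a number, and it shares that place with one other compound, as the limit of > 10000 nM in this assay, at which 2 of the 3 values shown sit, shows. Compound 4 `COc1ccc(C(=O)/C=C/c2cc(Cl)ccc2O)c2c1C=CC(C)(C)O2` differs from compound 3 by 5-chloro-2-hydroxyphenyl in place of furan-2-yl on a double-bonded chain carbon bound to a double-bonded chain carbon. Going by the values given here, the only measured step that touches this position is a step that the two limits leave unreadable from compound 2 to compound 3, and since both ends of it are limits its size cannot be read. Among the compounds with values here, no measured step therefore tells how large the change to compound 4 should be or in which direction; the one numbered value, that of compound 1, belongs to a compound differing in more than one place, so it gives no step either. With the evidence at hand, no step beyond the scatter can be predicted, and a further limit is as likely as a number. Compound 4 is expected to give about 6000 nM, with a range from 800 nM to 30000 nM. The expected step is an at least 1.6-fold lower number from compound 3 to compound 4 (0.22 log units; that floor lies within the scatter).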

Compound 4, half-maximal inhibitory concentration: 4230 nM
Estimate against measurement, compound 4: 1.4-fold (0.15 log units) above; the measured number falls inside the stated range.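

At this position on the chain, 5-chloro-2-hydroxyphenyl gives a number that can be read in this assay, whereas the two five-membered rings gave only limits. Putting this group in place of furan-2-yl brings an at least 2.3-fold lower number from compound 3 to compound 4 (0.37 log units; beyond the scatter), and putting it in place of thiophen-3-yl brings an at least 2.3-fold lower number from compound 2 to compound 4 (0.37 log units; beyond the scatter). Both steps are only floors, and the step between the two five-membered rings cannot be read, because compound 2 and compound 3 each stand at a limit: the limit of > 10000 nM in this assay, at which 2 of the 4 values shown sit.

From the compounds shown here alone, it remains open which part of the new group goes with the change: a phenyl ring carrying only the hydroxyl, or only the chlorine, would separate the two. It is also unsettled how other six-membered rings at this position, such as a pyridine or a methoxyphenyl, would compare.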